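The source may hold more compounds than are shown below. What is called first, only, known or untested is meant among the compounds shown, and "the series" means these compounds.

Of the compounds shown here, two have been tested so far. Compound 1 `Nc1nc(O)c(I)c(-c2ccccc2)n1` gives 8% in a functional assay on the whole organism for inhibition, with Rattus norvegicus as the target, at a dose of 100 mg/kg by the oral route; a higher number here means a stronger effect of the compound at the dose given, a lower number a weaker effect. Compound 2 `Oc1nc(O)c(Br)c(-c2ccccc2)n1` gives 58% in the same assay, which is the highest of the two numbers; its nearest neighbour is compound 1, whose number is lower by a gap beyond the usual scatter. For the measured compounds named here, the two compounds differ in more than one place, so no single step between them can be read off.

Compound 3 `Oc1nc(O)c(I)c(-c2ccccc2)n1` has not yet been measured. It differs from compound 2 in one place (iodo in place of bromo on an aromatic carbon). Going by the values given here, since no measured pair shows what this exchange does, the step is expected to be small, in either direction, and is estimated to stay within the scatter as a number 8 percentage points lower from compound 2 to compound 3 (within the scatter). Compound 3 is therefore expected to give about 50%, with a range from 20% to 80%.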

Compound 3, a percentage reported as inhibition, in the whole organism at one dose (the size of the read-out at that dose, not a potency): 48%
The estimate for compound 3 lay 2 percentage points above the measured number; measured number inside the range.
By their numbers in this assay, from the lowest: compound 1; then compounds 3 and 2 (each within the scatter of the next).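

In this assay, iodo in place of bromo on this aromatic carbon gives a number 10 percentage points lower from compound 2 to compound 3 (within the scatter), so the compounds shown do not separate these two halogens at this position. With iodo kept in place, hydroxy in place of amino on an aromatic carbon gives a number 40 percentage points higher from compound 1 to compound 3 (beyond the scatter), which shows that this exchange, unlike the halogen exchange, carries a large step in this assay. No measurement available here accounts for either step.

The compounds shown leave open whether a smaller chloro or a methyl group on the same carbon would stay within the scatter of compound 2 and compound 3. They also leave open whether the large step between amino and hydroxy would recur with bromo in place of iodo, or with a methoxy group in place of hydroxy.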